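A few compounds are considered here, and "the series" means these few. Any claim that something is new, unique, unknown or untested is made for them only; others in the source may bear on it.

Measured so far in an assay on HEK293 cells for displacement of a labelled ligand from 5-hydroxytryptamine receptor 7 (Homo sapiens); on this read-out higher numbers stand for weaker inhibition and lower numbers for stronger inhibition:
compound 1 `O=c1[nH]c2ccccc2n1CCCCCCN1CCN(c2ccccc2)CC1`: 20 nM
compound 2 `Cc1ccccc1N1CCN(CCn2c(=O)n(-c3ccccc3C)c3ccccc32)CC1`: 18000 nM
compound 3 `COc1cccc(-n2c(=O)n(CCN3CCN(c4ccccc4C)CC3)c3ccccc32)c1`: 2500 nM

Compound 3 holds the second highest of the three numbers. Going by the values given here, the only single-point step in the set is a 7.2-fold lower number from compound 2 to compound 3 (0.86 log units; beyond the scatter), brought about by 3-methoxyphenyl in place of 2-methylphenyl on an aromatic nitrogen. Among the compounds with values here, compound 1 lies far lower than compound 3, but it differs in the linker length, in the group on the aromatic nitrogen and in the ring on the piperazine, so no step connects the two.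

Compound 4 `COc1cccc(-n2c(=O)n(CCN3CCN(c4ccccc4)CC3)c3ccccc32)c1` differs from compound 3 by hydrogen in place of methyl on an aromatic carbon. Within the data shown here, no measured step bears on this change: the one step available concerns the ring on the other nitrogen. Compound 1 does carry the unsubstituted phenyl on the piperazine and gives the lowest value of the set, yet its other two differences leave that value unassignable to the methyl alone. With nothing to anchor it, the expected outcome is a step no larger than the scatter, if anything a somewhat lower number, written as a 1.7-fold lower number from compound 3 to compound 4 (0.22 log units; within the scatter). Compound 4 is accordingly estimated at 1500 nM, with a range from 400 nM to 6000 nM.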

Compound 4, inhibition constant: 864 nM
Compound 4: the middle estimate sits 1.7-fold (0.24 log units) above what was measured; measured number inside the range.
By their numbers in this assay, from the lowest: compound 1; then compound 4; then compound 3; then compound 2.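

In this assay, going from 2-methylphenyl to phenyl on the piperazine gives a 2.9-fold lower number from compound 3 to compound 4 (0.46 log units; beyond the scatter), so this position now has a measured step of its own, small but not lost in the scatter. Read beside a 7.2-fold lower number from compound 2 to compound 3 (0.86 log units; beyond the scatter), this makes two single-point changes in the series that take away a 2-methylphenyl, one on the aromatic nitrogen and one on the piperazine, and both lower the number; with only these two steps, this holds for compounds 2, 3 and 4 and no further. No independent evidence bears on why removing the methyl has this effect.

Compound 4 and compound 1 now share the unsubstituted phenyl on the piperazine but still differ in both linker length and the group on the aromatic nitrogen, so the contribution of each to the value of compound 1 remains unresolved. Also open, from the compounds shown here alone, is whether a chlorine atom or a methoxy group in place of the methyl on this ring would keep the number near that of compound 4 or return it toward that of compound 3.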